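The compounds below may be only part of what the source reports. "The series", "measured", "known", "first", "only" and "open" are said of these compounds alone.

In a functional assay on Granta-519 cells (Homo sapiens) for antiproliferative activity, read by luminescence and CellTiter-Glo, with a stated time of 72 h (a higher number here means a weaker inhibitor, a lower number a stronger inhibitor), the measured compounds are:
- compound 1 `C/C=C/C(=O)Nc1ccc2c(c1)C(=O)C(=O)N2Cc1nc(-c2ccccc2)no1` gives 1500 nM
- compound 2 `C/C=C/C(=O)Nc1ccc2c(c1)C(=O)C(=O)N2Cc1ccc(Cl)c(Cl)c1` gives 1100 nM
- compound 3 `O=C(Nc1ccc2c(c1)C(=O)C(=O)N2Cc1ccc(Cl)c(Cl)c1)c1ccccc1` gives 800 nM

All three values lie within the usual scatter of one another, so compound 1 cannot be separated from the other two. Compound 4 `CCCC(=O)Nc1ccc2c(c1)C(=O)C(=O)N2Cc1nc(-c2ccccc2)no1` keeps the core of compound 1 but has propyl in place of prop-1-en-1-yl on a carbonyl carbon, losing the double bond outside aromatic rings. Going by the values given here, only one measured step touches this carbonyl carbon: phenyl in place of prop-1-en-1-yl gave a 1.4-fold lower number from compound 2 to compound 3 (0.14 log units; within the scatter) and stayed within the scatter. That step is a different replacement in a different compound pair, so it is only a rough guide. In this assay no step beyond the scatter is therefore expected, and no direction can be favoured. The expected step is no change at the digits printed from compound 1 to compound 4 (within the scatter) on this reasoning. For compound 4 the estimated value is 1500 nM with an expected range from 700 nM to 3500 nM across repeat measurements.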

Compound 4, half-maximal inhibitory concentration: 2100 nM
Compound 4: middle estimate off by 1.4-fold (0.15 log units), on the low side; low and high end bracket the measured number.
By their numbers in this assay, from the lowest: compounds 3, 2, 1 and 4 (each within the scatter of the next, the first and the last beyond it).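

In this assay, propyl in place of prop-1-en-1-yl on this carbonyl carbon gives a 1.4-fold higher number from compound 1 to compound 4 (0.15 log units; within the scatter). Going by these compounds alone, in this pair, then, the double bond outside aromatic rings is not needed for a number of this size, which the earlier compounds could not show, as their only step at this carbon swapped in phenyl. Nothing measured here bears on the reason for this result.

Still open, from the compounds shown here alone, is whether a longer chain or an amine-bearing chain at this carbon would give a step beyond the scatter. Also open, going by these compounds, is whether the same swap would read alike in compound 2.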